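A few compounds are considered here, and "the series" means these few. Any claim that something is new, unique, unknown or untested is made for them only; others in the source may bear on it.

Three compounds sharing one core differ only in the aromatic group on the amide-type nitrogen of the carbamate. Compound 1 `CC(C)=CCC/C(C)=C/CC1Cc2c(OC(=O)Nc3cccc(F)c3)cc(=O)n(CCCO)c2CC1(C)C` carries a 3-fluorophenyl group there; in a functional assay on PANC-1 cells (Homo sapiens) for inhibition, read by MTT assay, with a stated time of 24 h, tested at 10 uM (on this read-out lower numbers stand for less inhibition and higher numbers for more inhibition at the one concentration tested (going by the name of the read-out)), compound 1 gives 0%. Compound 2 `CC(C)=CCC/C(C)=C/CC1Cc2c(OC(=O)Nc3ccc(F)cc3F)cc(=O)n(CCCO)c2CC1(C)C` carries a 2,4-difluorophenyl group, and in this assay compound 2 gives 15.6%. Compound 3 `CC(C)=CCC/C(C)=C/CC1Cc2c(OC(=O)Nc3ccc(Cl)cc3)cc(=O)n(CCCO)c2CC1(C)C` carries a 4-chlorophenyl group, and in this assay compound 3 gives 4.3%. Among these three numbers compound 3 stands second highest: a number 4.3 percentage points higher from compound 1 to compound 3 (within the scatter) is within the scatter, while a number 11.3 percentage points lower from compound 2 to compound 3 (beyond the scatter) is a modest step beyond it.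

Compound 4 `CC(C)=CCC/C(C)=C/CC1Cc2c(OC(=O)Nc3cccc(C(F)(F)F)c3)cc(=O)n(CCCO)c2CC1(C)C` is the next member of this series. The change from compound 3 is 3-(trifluoromethyl)phenyl in place of 4-chlorophenyl on an amide-type nitrogen. All three measured steps are swaps of this same aromatic group; the largest, a number 15.6 percentage points higher from compound 1 to compound 2 (beyond the scatter), is only modest, and a number 4.3 percentage points higher from compound 1 to compound 3 (within the scatter) did not move the read-out beyond the scatter. The expectation is therefore a small step, a number 1.7 percentage points higher from compound 3 to compound 4 (within the scatter), with no clear direction. Compound 4 is estimated at 6%, within a range from 0% to 20%.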

Compound 4, a percentage reported as inhibition, at one concentration (the size of the read-out at that concentration, not a potency): 6.7%
Compound 4: middle estimate off by 0.7 percentage points, on the low side; the range from low to high includes it.
By their numbers in this assay, from the lowest: compounds 1, 3, 4 and 2 (each within the scatter of the next, the first and the last beyond it).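

On the amide-type nitrogen, a bigger aromatic group brings no clear shift in this assay: 3-(trifluoromethyl)phenyl has 10 heavy atoms against 7 for 4-chlorophenyl, yet the result is a number 2.4 percentage points higher from compound 3 to compound 4 (within the scatter) and no real change, and trifluoromethyl in place of fluoro on an aromatic carbon gives a number 6.7 percentage points higher from compound 1 to compound 4 (within the scatter) and no real change either. Compound 2 stands apart from compound 1 and compound 3, but a number 8.9 percentage points lower from compound 2 to compound 4 (within the scatter) means compound 4 cannot be separated from compound 2 or from the other two. Nothing available here explains why these swaps change the read-out so little.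

Every group compared so far is a halogen-bearing phenyl ring. Going by these compounds, whether an amine or a carboxylic acid on that ring, or a longer chain in its place, would lift inhibition remains open.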